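The compounds below may be only part of what the source reports. "The series", "measured", "known", "first", "only" and "open" are said of these compounds alone.

Compound 1 `O=C(NC1CCCCC1)NS(=O)(=O)N1CCC(CCNC(=O)c2cscn2)CC1`: 23%
Compound 2 `Cc1cccc(C(=O)NCCC2CCN(S(=O)(=O)NC(=O)NC[C@@H]3C[C@@H]4C=C[C@@H]3C4)CC2)n1`: 20%

In a functional assay on the whole organism (blood) with Rattus norvegicus as the target, with stated times of 24 h and 1 h, at a dose of 5 mg/kg by the intraperitoneal route (a lower number here means a weaker effect, a higher number a stronger effect of the compound at the dose given), compound 1 gives 23%, and compound 2 gives 20%, a number within the scatter of compound 1, so the two show no difference that can be read. Compound 3 `Cn1cc(C(=O)NCCC2CCN(S(=O)(=O)NC(=O)NC[C@@H]3C[C@@H]4C=C[C@@H]3C4)CC2)c(=O)n(C)c1=O` is not yet measured. It differs from compound 2 at one place: a group of 10 heavy atoms (6 carbon, 2 nitrogen, 2 oxygen; one six-membered aromatic ring with 2 hetero atoms) in place of a group of 7 heavy atoms (6 carbon, 1 nitrogen; one six-membered aromatic ring with 1 hetero atom), on a carbonyl carbon. Going by the values given here, no measured pair shows such a change, so there is no guide to its size. Compound 3 is expected to give about 20%, with a range from 5% to 38%; the step expected is no change at the digits printed from compound 2 to compound 3 (within the scatter), none beyond the scatter.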

Compound 3, a percentage reported as activity, at one dose (the size of the read-out at that dose, not a potency): 23%
Compound 3: the middle estimate sits 3 percentage points below what was measured, within the range that was stated.
By their numbers in this assay, from the lowest: compounds 2, 1 and 3 (each within the scatter of the next).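

In this assay, the exchange of the 6-methylpyridin-2-yl group for a group of 10 heavy atoms with 4 hydrogen-bond acceptors, on a carbonyl carbon, gives a number 3 percentage points higher from compound 2 to compound 3 (within the scatter). This position therefore tolerates a larger ring with 2 hetero atoms and 2 double bonds outside aromatic rings, with no difference that can be read. Nothing measured here offers an explanation for this result.

Going by these compounds, it remains open whether a chain bearing a carboxylic acid or an amine on this carbonyl carbon would move the number beyond the scatter. The single dose also leaves potency unresolved.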